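Piperazine aryl swap: from methoxyphenyl to pyrimidinyl

The source may hold more compounds than are shown below. What is called first, only, known or untested is meant among the compounds shown, and "the series" means these compounds.

Compound 1 `CC1(c2ccccc2)CC(=O)N(CC(=O)N2CCN(c3cccc(Cl)c3)CC2)C1=O`: 300 mg/kg
Compound 2 `CC1(c2ccccc2)CC(=O)N(CC(=O)N2CCN(c3ccccc3Cl)CC2)C1=O`: "not active" (no number reported)
Compound 3 `COc1ccccc1N1CCN(C(=O)CN2C(=O)CC(C)(c3ccccc3)C2=O)CC1`: 100 mg/kg

In a functional assay on the whole organism (strain CD-1) with Mus musculus as the target, in the maximal electroshock model, with a stated time of 0.5 h (a higher number here means that more compound is needed for the effect, a lower number that less compound is needed), compound 3 gives 100 mg/kg, the lowest of the two numbers; compound 1 is nearest, and the step of a 3.0-fold lower number from compound 1 to compound 3 (0.48 log units; beyond the scatter) is modest but beyond the scatter. Compound 2 returned "not active" (no number reported), with no number.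

Compound 4 `CC1(c2ccccc2)CC(=O)N(CC(=O)N2CCN(c3ncccn3)CC2)C1=O` differs from compound 3 by pyrimidin-2-yl in place of 2-methoxyphenyl on an amine nitrogen in a ring. Among the compounds with values here, no measured step covers this exact change. Within the data shown here, the only related step, a 3.0-fold lower number from compound 1 to compound 3 (0.48 log units; beyond the scatter), shows that exchanging the group on this ring nitrogen shifts the result modestly, while compound 2 shows such a change can also end activity. A modest rise in the dose is therefore expected, a 2.0-fold higher number from compound 3 to compound 4 (0.30 log units; within the scatter), giving an estimate for compound 4 of 200 mg/kg, within 100 mg/kg to 400 mg/kg.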

Compound 4, minimum effective dose: "not active" (no number reported)
Compound 4: no number reported; the estimate stays without a comparison.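

Compound 4 gives no number, so no step from compound 3 can be read, and nothing measured here explains the result. Left open is whether any other group on this ring nitrogen would need less compound than compound 3.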